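The compounds below may be only part of what the source reports. "The series", "measured", "known", "first", "only" and "open" are said of these compounds alone.

Compound 1 `CC[C@@H]1C(=O)N(C)c2cnc(-n3ccc4cc(F)ccc43)nc2N1C1CCCC1`, compound 2 `CCC1C(=O)N(C)c2cnc(-n3ccc4cc(C(N)=O)ccc43)nc2N1c1ccn(C)n1` and compound 3 `CCC1C(=O)N(C)c2cnc(Nc3ccc(S(=O)(=O)NCC(C)C)cc3)nc2N1c1ccn(C)n1` share a core and were tested in a functional assay on NCI-H1975 cells (Homo sapiens) for antiproliferative activity, read by CCK-8 assay, with a stated time of 72 h; on this read-out higher numbers stand for weaker inhibition of growth and lower numbers for stronger inhibition of growth. Compound 1 gives 46500 nM, and compound 3 gives 15000 nM. Within the data shown here, compound 2 is reported as "not active" (no number reported) in this assay, so no number fixes where it stands, and no step from it to another compound can be measured. Compound 4 `CCC1C(=O)N(C)c2cnc(-n3ccc4cc(C(=O)NC5CCCC5)ccc43)nc2N1c1ccn(C)n1` has not been tested. It differs from compound 2 by cyclopentyl in place of hydrogen on an amide-type nitrogen. Among the measured compounds shown here, with no measured step for this change, the account expects at most a small shift, most likely toward weak inhibition of growth that remains close to the scatter of the other two compounds. Compound 4 is estimated at 30000 nM in this assay, within 8000 nM to 100000 nM.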

Compound 4, concentration for 50% growth inhibition: "not active" (no number reported)
Nothing numeric was reported for compound 4, so the estimate cannot be set against anything.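

In this assay, among these compounds, neither compound 2 nor compound 4 carries a number, so no step between them can be read. As far as these compounds go, whether cyclopentyl in place of hydrogen changes growth inhibition stays open, and no evidence bears on this result.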